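Removing the Bromo Group Once More on Another Core

The source may hold more compounds than are shown below. What is called first, only, known or untested is meant among the compounds shown, and "the series" means these compounds.

Compound 1 `CNC(=O)c1cc(Oc2ccc(NC(=O)c3nn(-c4ccc(Br)cc4F)c(=O)cc3C)cc2F)ccn1` gives 2830 nM in a functional assay on HepG2 cells (Homo sapiens) for cytotoxicity, read by MTT assay, with a stated time of 72 h; a lower number here means a stronger inhibitor, a higher number a weaker inhibitor. Compound 2 `CNC(=O)c1cc(Oc2ccc(NC(=O)c3nn(-c4ccccc4F)c(=O)cc3C)cc2F)ccn1` differs from it by hydrogen in place of bromo on an aromatic carbon. In this assay compound 2 reaches only a limit, > 40000 nM. The result is an at least 14-fold higher number from compound 1 to compound 2 (1.15 log units; beyond the scatter). Compound 3 `O=C(Nc1ccc(Oc2ncnc3ccsc23)c(F)c1)c1nn(-c2ccc(Br)cc2)ccc1=O` rests on a different core, and the difference between the two cores is not broken down here. In this assay compound 3 gives 10700 nM. Compound 4 `O=C(Nc1ccc(Oc2ncnc3ccsc23)c(F)c1)c1nn(-c2ccccc2)ccc1=O` differs from compound 3 by hydrogen in place of bromo on an aromatic carbon. Going by the values given here, this is the same kind of change as the one between compound 1 and compound 2, yet there the carbon was also meta to a fluoro group, which is absent around the place in compound 3. The expected step is a 5.6-fold higher number from compound 3 to compound 4 (0.75 log units; beyond the scatter), resting on an at least 14-fold higher number from compound 1 to compound 2 (1.15 log units; beyond the scatter). Compound 4 is therefore expected to give 60000 nM, between 20000 nM and 200000 nM.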

Compound 4, half-maximal inhibitory concentration: 13500 nM
The estimate for compound 4 lay 4.4-fold (0.65 log units) above the measured number, and the stated range ends above it.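

Replacing bromo with hydrogen on the core of compound 3 gives a 1.3-fold higher number from compound 3 to compound 4 (0.10 log units; within the scatter) in this assay. The same change therefore does not carry over in size from one core to the other: the same change on two cores in this assay, an at least 14-fold higher number (1.15 log units; beyond the scatter) from compound 1 to compound 2 and a 1.3-fold higher number (0.10 log units; within the scatter) from compound 3 to compound 4, at least 11-fold (1.04 log units) apart, beyond the scatter of two such steps. Compound 2 sits at a limit of the assay, so the full size of the earlier step is not known, and the two pairs do not show which difference between the cores goes with the gap: the limit of > 40000 nM in this assay, at which 1 of the 4 values shown sits.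

The compounds shown leave open whether a chloro or a methoxy group in the place of the bromo would track the bromo compound on either core. They also leave open how the 4-bromophenyl to phenyl change reads on any further core.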